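This account rests on a few compounds, and the source may have more. Where it says the series, first, only, none or still open, it means among the compounds named here.

Compound 1, with the structure `CC(C)N(C(=O)CN1C=CN(c2ccccc2)C(=O)C(Cc2n[nH]c3ccccc23)C1=O)c1ccc(F)cc1`, gives 282 nM in a functional assay on CHO cells for agonist activity at Melanocortin receptor 4 (Homo sapiens), read by a luciferase reporter, with a stated time of 4 h; on this read-out lower numbers stand for an effect already at smaller amounts and higher numbers for an effect only at larger amounts of compound. Among the three compounds measured it holds the second highest number. Its closest neighbour is compound 3, `CC(C)N(C(=O)CN1C=CN(c2ccccc2)C(=O)C(Cc2n[nH]c3cc(F)ccc23)C1=O)c1ccc(F)cc1`, which gives 178 nM; the change is a 1.6-fold lower number from compound 1 to compound 3 (0.20 log units; within the scatter). The furthest is compound 2, `CC(C)N(C(=O)CN1C=CN(c2ccccc2)C(=O)C(Cc2n[nH]c3ccccc23)C1=O)c1ccccc1`, which gives 3240 nM; that change is an 11-fold higher number from compound 1 to compound 2 (1.06 log units; beyond the scatter).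

Compound 4, `COC1(Cc2n[nH]c3ccccc23)C(=O)N(CC(=O)N(c2ccc(F)cc2)C(C)C)C=CN(c2ccccc2)C1=O`, has not been measured. It differs from compound 1 by methoxy in place of hydrogen on a saturated ring carbon. Neither measured step speaks to this change: both swapped fluoro and hydrogen on an aromatic carbon, whereas here a methoxy enters on a saturated ring carbon of the seven-membered ring. So no precedent sets the size or direction, and the expectation rests on the general observation that a new group at such a place often shifts the number somewhat. A moderate step toward a higher number is therefore expected, a 2.1-fold higher number from compound 1 to compound 4 (0.33 log units; beyond the scatter), with wide uncertainty. Compound 4 is estimated at 600 nM, with a likely range from 150 nM to 2500 nM.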

Compound 4, half-maximal effective concentration: 44.7 nM
The estimate for compound 4 lay 13-fold (1.13 log units) above the measured number; the measured number lies below the stated range.
By their numbers in this assay, from the lowest: compound 4; then compounds 3 and 1 (each within the scatter of the next); then compound 2.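

On this saturated ring carbon of the seven-membered non-aromatic ring, methoxy in place of hydrogen brings a 6.3-fold lower number from compound 1 to compound 4 (0.80 log units; beyond the scatter) in this assay. Within the data shown here, the earlier steps only exchanged fluoro and hydrogen on aromatic carbons, so this is the first sign that the saturated ring carbon can carry a new group and that the number can fall when it does. No measurement shown here explains the drop.

With methoxy as the only group shown at this carbon, it remains open whether a methyl, a hydroxyl or a longer ethoxy chain would have a similar effect. On these data alone, it also remains open whether methoxy at this carbon would give a similar step with the extra fluoro of compound 3 present.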